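Cytotoxicity series: fluoro for bromo on the aryl amide

The compounds below may be only part of what the source reports. "The series", "measured", "known", "first", "only" and "open" are said of these compounds alone.

Measured so far in a toxicity assay on WI-38 cells (Homo sapiens) for inhibition, read by MTT assay, with a stated time of 72 h; a lower number here means a stronger inhibitor, a higher number a weaker inhibitor:
compound 1 `Cc1ccc(N2CCCC2)c(C(=O)Nc2ccc(CNC(=O)OCc3cccnc3)cc2)c1` gives 40600 nM
compound 2 `COc1ccc(N2CCCC2)c(C(=O)Nc2ccc(CNC(=O)OCc3cccnc3)cc2)c1` gives 35600 nM
compound 3 `O=C(NCc1ccc(NC(=O)c2cc(Br)ccc2N2CCCC2)cc1)OCc1cccnc1` gives > 100000 nM

Compound 3 stands at the assay limit, a reading that is a limit and not a number (the limit of > 100000 nM in this assay, at which 1 of the 3 values shown sits). Going by the values given here, of the three compounds it is the only one without a measured value. Compound 4 `O=C(NCc1ccc(NC(=O)c2cc(F)ccc2N2CCCC2)cc1)OCc1cccnc1` differs from it by fluoro in place of bromo on an aromatic carbon.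

Among the compounds with values here, the steps that bear on this change are an at least 2.4-fold higher number from compound 1 to compound 3 (0.39 log units; beyond the scatter) and an at least 2.8-fold higher number from compound 2 to compound 3 (0.44 log units; beyond the scatter), both beyond the scatter; a 1.1-fold lower number from compound 1 to compound 2 (0.06 log units; within the scatter) is within it. Within the data shown here, no measured step involves fluoro, so its weight on the number is unknown. Compound 4 is expected to sit between the values of compound 1 and compound 2 and the limit, estimated at 60000 nM with a range of 25000 nM to 140000 nM, so the expected step is an at least 1.6-fold lower number from compound 3 to compound 4 (0.22 log units; that floor lies within the scatter).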

Compound 4, half-maximal inhibitory concentration: > 100000 nM
Compound 4 gave a limit, no number (the forecaster's own chance of this, stated with the estimate: 40%); at least 1.6-fold (0.22 log units) between middle value and limit.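

In this assay compound 4 reads as a limit and not a number. Fluoro in place of methoxy gives an at least 2.8-fold higher number from compound 2 to compound 4 (0.44 log units; beyond the scatter), and fluoro in place of methyl gives an at least 2.4-fold higher number from compound 1 to compound 4 (0.39 log units; beyond the scatter), so on this aromatic carbon, para to the pyrrolidin-1-yl group, the step away from the measured compounds is not confined to bromo. The step between bromo and fluoro cannot be read: the limit of > 100000 nM in this assay, at which 2 of the 4 values shown sit.

As far as these compounds go, how far compound 3 and compound 4 lie past the limit stays open. Also open, from the compounds shown here alone, is whether an amine or a carboxylic acid at this position would give a measured value, as methyl and methoxy do.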